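A few compounds are considered here, and "the series" means these few. Any claim that something is new, unique, unknown or untested is made for them only; others in the source may bear on it.

Compound 3 `O=C(Nc1ccnnc1)c1cc(N2CCNCC2)ccc1OCc1ccccc1` is the starting point here. In a physicochemical assay for solubility, measured as kinetic solubility (on this read-out lower numbers stand for lower solubility and higher numbers for higher solubility), compound 3 gives 98000 nM, the lowest of the two numbers available. Compound 1 `CN1CC2(C1)CN(c1ccc(OCc3ccccc3)c(C(=O)Nc3ccnnc3)c1)C2` gives 198000 nM in this assay, and the step of a 2.0-fold lower number from compound 1 to compound 3 (0.31 log units; beyond the scatter) sets the two apart. Compound 2 `N#Cc1cccc(NC(=O)c2cc(C(F)(F)F)ccc2OCc2ccc(F)cc2)c1` gives only a limit, < 1000 nM, which marks (the limit of < 1000 nM in this assay, at which 1 of the 3 values shown sits). Compound 4 `O=C(Nc1ccnnc1)c1cc(N2CCC(F)CC2)ccc1OCc1ccccc1` is not yet measured; it differs from compound 3 by 4-fluoropiperidin-1-yl in place of piperazin-1-yl on an aromatic carbon. Going by the values given here, only the step from compound 1 to compound 3 bears on this change, and it was modest, with the ring having the donor giving the lower number. For compound 4 a lower number is expected, a 3.3-fold lower number from compound 3 to compound 4 (0.51 log units; beyond the scatter), so the estimate for compound 4 is 30000 nM, with a range from 8000 nM to 100000 nM.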

Compound 4, solubility: 20000 nM
For compound 4 the middle estimate is 1.5-fold (0.18 log units) above the measured one; the range from low to high includes it.
By their numbers in this assay, from the lowest: compound 4; then compound 3; then compound 1. At a limit, below all of these: compound 2.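

In this assay, the place para to the benzyloxy group responds strongly to the ring it carries: a 4.9-fold lower number from compound 3 to compound 4 (0.69 log units; beyond the scatter), and a 9.9-fold lower number from compound 1 to compound 4 (1.00 log units; beyond the scatter). Piperazin-1-yl, the ring with the hydrogen-bond donor, now falls between the other two groups, so that donor alone does not set the order. Nothing measured here explains these differences. Where plain piperidin-1-yl would fall remains open, and it would separate the effect of the fluorine from that of the ring. A morpholine ring or a carboxylic acid at this place is also untested in the compounds shown.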